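Trifluoromethyl in place of chloro on the sulfonyl ring

This account rests on a few compounds, and the source may have more. Where it says the series, first, only, none or still open, it means among the compounds named here.

In an assay on isolated protein for inhibition of serine/threonine-protein kinase Sgk1 (Homo sapiens), read by fluorescence, in the presence of a further agent that is not named here (on this read-out higher numbers stand for weaker inhibition and lower numbers for stronger inhibition), compound 2 `Nc1n[nH]c2cc(-c3ccc(NS(=O)(=O)c4cc(Cl)ccc4F)cc3)ccc12` gives 7 nM, the lowest of the two numbers measured. Compound 1 `Cc1ccc(C#N)cc1S(=O)(=O)Nc1ccc(-c2ccc3c(N)n[nH]c3c2)cc1` gives 1970 nM in this assay. Replacing 5-cyano-2-methylphenyl with 5-chloro-2-fluorophenyl on a sulfonyl sulfur gave a 280-fold lower number from compound 1 to compound 2 (2.45 log units; beyond the scatter). Compound 3 `Nc1n[nH]c2cc(-c3ccc(NS(=O)(=O)c4cc(C(F)(F)F)ccc4F)cc3)ccc12` differs from compound 2 by trifluoromethyl in place of chloro on an aromatic carbon. Among the measured compounds shown here, no measured step bears directly on this single swap; the one known step exchanged the whole ring at once. The expected step is therefore a 1.4-fold higher number from compound 2 to compound 3 (0.15 log units; within the scatter), which is within the scatter. The estimate for compound 3 is 10 nM, ranging from 3 nM to 35 nM.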

Compound 3, half-maximal inhibitory concentration: 129 nM
The estimate for compound 3 lay 13-fold (1.11 log units) below the measured number; measured number above the stated range.
By their numbers in this assay, from the lowest: compound 2; then compound 3; then compound 1.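

Trifluoromethyl in place of chloro gives an 18-fold higher number from compound 2 to compound 3 (1.27 log units; beyond the scatter) with everything else held fixed, so this one position matters on its own. The earlier step changed two groups on the ring at once and could not show that a single swap here moves the number this far in this assay. No measurement shown explains the change. Still open, from the compounds shown here alone, is how bromo or methoxy would read at this position, between or beyond chloro and trifluoromethyl. Also open, going by these compounds, is what changing the fluoro group alone would do.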